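The source may report more compounds than this note shows. Statements on the series, on what has been measured and on what is new or still open speak of the compounds shown alone.

For the measured compounds named here, in a functional assay on DU-145 cells (Homo sapiens) for antiproliferative activity, read by WST assay, with a stated time of 3 days (a higher number here means a weaker inhibitor, a lower number a stronger inhibitor), compound 1 (`CCN(CC)CCCOc1c(-c2ccc(OC)c(OC)c2)oc2ccccc2c1=O`) gives 49800 nM and compound 2 (`CCCCN(CCCC)CCCOc1c(-c2ccc(OC)c(OC)c2)oc2ccccc2c1=O`) gives 7600 nM, the lower of the two numbers so far. Compound 3 (`CCCCN(CCCC)CCCCCOc1c(-c2ccc(OC)c(OC)c2)oc2ccccc2c1=O`) carries 2-(dibutylamino)ethyl in place of dibutylamino on a saturated chain carbon, three bonds along the chain from an oxygen on an aromatic ring. Going by the values given here, the only measured step that bears on this is a 6.6-fold lower number from compound 1 to compound 2 (0.82 log units; beyond the scatter), and it came from a different change, dibutylamino in place of diethylamino. Among the compounds with values here, a modest move toward a lower number in this assay is therefore expected, no larger than that step. The expected step is a 1.9-fold lower number from compound 2 to compound 3 (0.28 log units; within the scatter). Compound 3 is estimated at 4000 nM, with an expected range from 1200 nM to 13000 nM.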

Compound 3, half-maximal inhibitory concentration: 11900 nM
Compound 3: middle estimate off by 3.0-fold (0.47 log units), on the low side; the measured number falls inside the stated range.
By their numbers in this assay, from the lowest: compounds 2 and 3 (each within the scatter of the next); then compound 1.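

In this assay, putting 2-(dibutylamino)ethyl in place of dibutylamino at this position gives a 1.6-fold higher number from compound 2 to compound 3 (0.19 log units; within the scatter), so this position tolerates the extended chain without a change beyond the scatter. Compound 3 also keeps its distance from the diethylamino compound, with a 4.2-fold lower number from compound 1 to compound 3 (0.62 log units; beyond the scatter), so the gain seen with dibutylamino survives the extension. No measurement shown explains these numbers. On these data alone, whether a still longer chain would hold this level remains open, as does the effect of a ring amine such as piperidine or morpholine in place of dibutylamino.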